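A few compounds are considered here, and "the series" means these few. Any claim that something is new, unique, unknown or untested is made for them only; others in the source may bear on it.

Compound 1 `Fc1ccc(N2CCN(c3nc(-n4ccc5ccccc54)c4ccccc4n3)CC2)cc1`: 50 ug/mL
Compound 2 `c1ccc(N2CCN(c3nc(-n4ccc5ccccc54)c4ccccc4n3)CC2)cc1`: 50 ug/mL
Compound 3 `CN1CCN(c2nc(-c3cn(C)c4ccccc34)c3ccccc3n2)CC1`: 50 ug/mL

In a functional assay on KB cells (Homo sapiens) for antiproliferative activity, read by MTT assay (a lower number here means a stronger inhibitor, a higher number a weaker inhibitor), compound 2 gives 50 ug/mL, level with compound 1 and compound 3 at the digits shown. Compound 4 `c1ccc(N2CCN(c3nc(-n4ccc5ccccc54)c4ccccc4n3)CC2)nc1` differs from compound 2 in one place: pyridin-2-yl in place of phenyl on an amine nitrogen in a ring. Within the data shown here, the only measured step touching that phenyl is no change at the digits printed from compound 1 to compound 2 (within the scatter). Among the measured compounds shown here, compound 3 differs in more than one place and offers no such step. For the measured compounds named here, no measured pair makes this exact swap, so the evidence is thin, and no shift beyond the scatter is expected in this assay. The estimated step is no change at the digits printed from compound 2 to compound 4 (within the scatter). Compound 4 is expected at about 50 ug/mL, with an estimated range of 20 ug/mL to 80 ug/mL.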

Compound 4, half-maximal inhibitory concentration: 50 ug/mL
Beside the measured number, compound 4's estimate shows no gap at the digits printed; the measured number falls inside the stated range.
By their numbers in this assay, from the lowest: compounds 1, 2, 3 and 4 (each within the scatter of the next).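

In this assay, pyridin-2-yl in place of phenyl on the ring amine nitrogen gives no change at the digits printed from compound 2 to compound 4 (within the scatter), and pyridin-2-yl in place of 4-fluorophenyl gives no change at the digits printed from compound 1 to compound 4 (within the scatter). Adding a ring nitrogen, and with it one hydrogen-bond acceptor by count, therefore leaves the number as flat as removing the fluoro did, so this position now shows the same printed value with three different aromatic rings. No measurement is available to explain this flat result. Still open, going by these compounds, is whether a non-aromatic group here, such as cyclohexyl or a chain ending in a carboxylic acid, would move the number.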